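A few compounds are considered here, and "the series" means these few. Any claim that something is new, unique, unknown or untested is made for them only; others in the source may bear on it.

Working notes on the series. The shared core is carried by compound 1 `COc1cc(-c2nn(-c3cccc(NC(=O)Nc4ccc(Cl)c(Cl)c4)c3)cc2-c2ccncc2)ccc1Cl` and compound 2 `O=C(Nc1cccc(-n2cc(-c3ccncc3)c(-c3ccc(Cl)c(O)c3)n2)c1)Nc1ccc(Cl)c(Cl)c1`; in a functional assay on RPMI-8226 cells (Homo sapiens) for inhibition, read by sulforhodamine B assay, with a stated time of 48 h (on this read-out lower numbers stand for stronger inhibition of growth and higher numbers for weaker inhibition of growth), compound 1 gives 388 nM and compound 2 gives 1030 nM, so compound 1 stands as the lower of the two numbers. Going by the values given here, the one step measured so far, a 2.7-fold higher number from compound 1 to compound 2 (0.42 log units; beyond the scatter), is the hydrogen in place of methyl on an oxygen on an aromatic ring.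

Compound 3 `COc1cc(-c2nn(-c3cccc(NC(=O)c4ccccc4)c3)cc2-c2ccncc2)ccc1Cl` differs from compound 1 elsewhere: phenyl in place of (3,4-dichlorophenyl)amino on a carbonyl carbon. Among the compounds with values here, no measured step touches the carbonyl carbon or the (3,4-dichlorophenyl)amino group, so the step from compound 1 to compound 2 does not bear on it, and the size of the change in this assay cannot be read from the data. The removal of a group of this size is expected to cost potency, so a step beyond the scatter towards a higher number is expected, a 5.2-fold higher number from compound 1 to compound 3 (0.71 log units; beyond the scatter). For compound 3 the estimate is 2000 nM, within 600 nM to 8000 nM.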

Compound 3, concentration for 50% growth inhibition: 850 nM
Estimate against measurement, compound 3: 2.4-fold (0.37 log units) above; low and high end bracket the measured number.
By their numbers in this assay, from the lowest: compound 1; then compounds 3 and 2 (each within the scatter of the next).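

Going by these compounds alone, until now only the oxygen substituent had been probed; the carbonyl carbon is now read for the first time in this assay as well. With phenyl in place of (3,4-dichlorophenyl)amino on that carbon, a 2.2-fold higher number from compound 1 to compound 3 (0.34 log units; beyond the scatter) is a modest step, so growth inhibition persists without the (3,4-dichlorophenyl)amino group, while compound 1 keeps the lower number. No measurement on hand explains this step.

This single change removes the two chlorine atoms and the amino nitrogen together, so their separate contributions cannot be told apart. As far as these compounds go, how a plain phenylamino group, a 4-chlorophenylamino group or a saturated ring such as cyclohexyl would read on the same carbonyl carbon remains open.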